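Fluoro for Hydrogen on Two Cores: Working Notes

This account rests on a few compounds, and the source may have more. Where it says the series, first, only, none or still open, it means among the compounds named here.

Measured so far:
compound 1 `COc1ccc(N(C)c2ccnc(Cl)n2)cc1`, 917 nM
compound 2 `COc1ccc(N(C)c2ccnc(Cl)n2)cc1F`, 241 nM
compound 3 `COc1ccc(N(C)c2cc(C)nc(C)n2)cc1`, 322 nM

In a functional assay on HeLa cells (Homo sapiens) for antiproliferative activity, read by MTT assay, with a stated time of 48 h (a higher number here means a weaker inhibitor, a lower number a stronger inhibitor), compound 1 gives 917 nM. Compound 2 carries fluoro in place of hydrogen on an aromatic carbon and gives 241 nM, so that a 3.8-fold lower number from compound 1 to compound 2 (0.58 log units; beyond the scatter).

Compound 3 has a different core from compound 1; the difference between the two cores is not broken down here. In this assay compound 3 gives 322 nM, which sits within the scatter of compound 2 and is a lower number than compound 1.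

Compound 4 `COc1ccc(N(C)c2cc(C)nc(C)n2)cc1F` repeats the change on the core of compound 3: fluoro in place of hydrogen on an aromatic carbon. The surroundings are not identical, since the change in compound 2 stands meta to a group of 9 heavy atoms while here it stands meta to a large group, so this is the same kind of change rather than the same change. For the measured compounds named here, the expectation is a step of a 2.7-fold lower number from compound 3 to compound 4 (0.43 log units; beyond the scatter), somewhat damped beside a 3.8-fold lower number from compound 1 to compound 2 (0.58 log units; beyond the scatter), because the only precedent is the single pair a 3.8-fold lower number from compound 1 to compound 2 (0.58 log units; beyond the scatter). Compound 4 is therefore estimated at 120 nM, with a likely range from 50 nM to 300 nM.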

Compound 4, half-maximal inhibitory concentration: 471 nM
Beside the measured number, compound 4's estimate is 3.9-fold (0.59 log units) below it; the measured number lies above the stated range.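

In this assay, fluoro in place of hydrogen on an aromatic carbon does not carry over from one core to the other: the same change on two cores in this assay, a 3.8-fold lower number (0.58 log units; beyond the scatter) from compound 1 to compound 2 and a 1.5-fold higher number (0.17 log units; within the scatter) from compound 3 to compound 4, 5.6-fold (0.75 log units) apart, beyond the scatter of two such steps. For the compounds shown here, on the second core the step reads a 1.5-fold higher number from compound 3 to compound 4 (0.17 log units; within the scatter), so the lower number seen on the core of compound 1 has no counterpart there, and a gain on one core cannot be taken as a forecast for another. Going by these compounds alone, with only two pairs, this shows that the outcome of the change differs between these two cores; it does not show which feature of the cores is responsible, how the change would behave on any third core, or whether either step reflects a general rule.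

The compounds shown leave open which part of the core governs the outcome, for example how the change reads on a core carrying an amine or a nitrile in place of the chloro group. Also open, from the compounds shown here alone, is whether a chloro group or a trifluoromethyl group on the same aromatic carbon would follow fluoro on either core.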